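A few compounds are considered here, and "the series" means these few. Any claim that something is new, unique, unknown or untested is made for them only; others in the source may bear on it.

Compound 1 `O=C(/C(=C\c1ccc(Br)cc1)S(=O)(=O)c1ccc(Br)cc1)c1ccccc1O`: in a functional assay on DU-145 cells (Homo sapiens) for inhibition, read by trypan blue exclusion, with a stated time of 96 h (a higher number here means a weaker inhibitor of growth, a lower number a stronger inhibitor of growth), compound 1 reaches only a limit of the assay, > 100000 nM.
Compound 2 `O=C(/C(=C\c1ccccc1OCc1ccccc1)S(=O)(=O)c1ccc(F)cc1)c1ccc(Cl)cc1`: in this assay compound 2 gives 1000 nM.
Compound 3 `O=C(/C(=C\c1c[nH]c2ccccc12)S(=O)(=O)c1ccc(Br)cc1)c1ccc(Br)cc1`: in this assay compound 3 gives 25000 nM.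

Of the two numbered values, compound 2 has the lowest number, and compound 3 lies far beyond the scatter from it, so compound 2 is the stronger inhibitor of growth of these two. Compound 4 `O=C(/C(=C\c1ccccc1OCc1ccccc1)Sc1ccc(Br)cc1)c1ccc(Cl)cc1` has not yet been measured. It differs from compound 2 in one place: (4-bromophenyl)sulfanyl in place of (4-fluorophenyl)sulfonyl on a double-bonded chain carbon bound to a carbonyl carbon and a double-bonded chain carbon. Within the data shown here, no pair of measured compounds differs in just this way, so the step has no direct precedent here. A moderate rise in the number, beyond the scatter, is expected, namely the step of a 5.0-fold higher number from compound 2 to compound 4 (0.70 log units; beyond the scatter). Compound 4 is therefore estimated at 5000 nM in this assay, with a range from 1000 nM to 30000 nM.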

Compound 4, concentration for 50% growth inhibition: 10000 nM
Compound 4: the middle estimate sits 2.0-fold (0.30 log units) below what was measured; the measured number falls inside the stated range.
By their numbers in this assay, from the lowest: compound 2; then compound 4; then compound 3. At a limit, above all of these: compound 1.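

On the double-bonded chain carbon bound to a carbonyl carbon and a double-bonded chain carbon, putting (4-bromophenyl)sulfanyl in place of (4-fluorophenyl)sulfonyl gives a 10-fold higher number from compound 2 to compound 4 (1.00 log units; beyond the scatter) in this assay, so growth inhibition at this position weakens with this change. The swap changes two things at once, sulfonyl to sulfanyl and fluorine to bromine, so this single step cannot divide the loss between them. Nothing shown here bears on the cause of this step.

Still open, as far as these compounds go, is how (4-fluorophenyl)sulfanyl or (4-bromophenyl)sulfonyl would compare with compound 2. Also open, from the compounds shown here alone, is what an amine or a carboxylic acid in place of the halogen would do.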